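The compounds below may be only part of what the source reports. "The series", "measured", "known", "first", "only" and "open" are said of these compounds alone.

Measured so far:
compound 1 `Nc1ccc2cccc(OC3CCCCC3)c2n1` — 361 nM
compound 2 `COCC(C)Oc1cccc2ccc(N)nc12` — 606 nM
compound 3 `CCCOc1cccc2ccc(N)nc12` — 1100 nM

Among the compounds with values here, in an assay on cells with melanin-concentrating hormone receptor 1 (Homo sapiens) as the target, read by radioligand binding (on this read-out lower numbers stand for stronger inhibition and higher numbers for weaker inhibition), compound 1 gives the lowest of the three numbers; compound 2 sits nearest, compound 3 furthest, with a 3.0-fold higher number from compound 1 to compound 3 (0.48 log units; beyond the scatter) as the only step beyond the scatter. The step of a 1.7-fold higher number from compound 1 to compound 2 (0.22 log units; within the scatter) stays within it.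

Compound 4 `Nc1ccc2cccc(OC3CCCC3)c2n1` is not yet measured. It differs from compound 1 by cyclopentyl in place of cyclohexyl on an oxygen on an aromatic ring. Both measured steps away from compound 1 swap the cyclohexyl for another group on the same oxygen, and both move toward higher numbers, one modestly. On that basis a small rise or no change beyond the scatter is expected, giving a 1.4-fold higher number from compound 1 to compound 4 (0.14 log units; within the scatter). For compound 4 the expected value is 500 nM, with a range of 200 nM to 1300 nM.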

Compound 4, half-maximal inhibitory concentration: > 2000 nM
Compound 4 ended at the assay's limit; the forecaster's own chance of this, stated with the estimate: 3%; middle value at least 4.0-fold (0.60 log units) away from the limit.
By their numbers in this assay, from the lowest: compounds 1, 2 and 3 (each within the scatter of the next, the first and the last beyond it). At a limit, above all of these: compound 4.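

In this assay, a carbon ring on this oxygen does not by itself keep the number low: cyclopentyl in place of cyclohexyl gives an at least 5.5-fold higher number from compound 1 to compound 4 (0.74 log units; beyond the scatter). Cyclopentyl also falls behind the open-chain 1-(methoxymethyl)ethyl, with an at least 3.3-fold higher number from compound 2 to compound 4 (0.51 log units; beyond the scatter), while an at least 1.8-fold higher number from compound 3 to compound 4 (0.25 log units; that floor lies within the scatter) leaves it unseparated from propyl. The value of compound 4 is a limit of the assay, not a number: the limit of > 2000 nM in this assay, at which 1 of the 4 values shown sits.

On these data alone, how far compound 4 lies beyond that limit remains unknown. Also open, as far as these compounds go, is whether a larger ring such as cycloheptyl, or a chain carrying an amine, would give a lower number than compound 1.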